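Ring methyl on the one compound with a number

This account rests on a few compounds, and the source may have more. Where it says the series, first, only, none or still open, it means among the compounds named here.

Of the compounds shown here, three have been read in a functional assay on the whole organism for agonist activity, with Mus musculus as the target; on this read-out higher numbers stand for an effect only at larger amounts of compound and lower numbers for an effect already at smaller amounts. Compound 1 (`CCc1nccn1CC#CCN1CCCC1=O`) gives > 100 mg/kg, which is a limit of the assay and not a number. Compound 2 (`O=C1CCCN1CC#CCn1cnc2ccccc21`) gives > 100 mg/kg, again a limit of the assay and not a number. The picture so far is lopsided: the limit of > 100 mg/kg in this assay, at which 2 of the 3 values shown sit. Among the compounds with values here, compound 3 (`CC(=O)N(C)C(C)C#CCn1ccnc1`) gives 3 mg/kg, the only true number in the set, and so serves as the sole reference point. Compounds 1, 2 and 3 differ in more than one place, so no single-change step can be read among them.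

Compound 4 (`CC(=O)N(C)C(C)C#CCn1cncc1C`) departs from compound 3 in one place only: methyl in place of hydrogen on an aromatic carbon. This is methyl in place of hydrogen on an aromatic carbon. Within the data shown here, no measured pair isolates such a change, so the expectation is anchored only on compound 3 at 3 mg/kg. A moderate shift towards larger doses is expected, beyond the usual scatter, with a real chance that the assay reports only a limit. The estimated move is a 5.0-fold higher number from compound 3 to compound 4 (0.70 log units; beyond the scatter). For compound 4 the expected value is 15 mg/kg, with an estimated range from 3 mg/kg to 80 mg/kg.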

Compound 4, dose for half-maximal effect: > 100 mg/kg
Compound 4: a limit, no number; the forecaster's own chance of this, stated with the estimate: 35%; at least 6.6-fold (0.82 log units) between middle value and limit.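

Methyl in place of hydrogen on an aromatic carbon, next to the ring nitrogen and next to the ring atom that bears a large group, is the first change in the series that can be read on its own, and in this assay it gives an at least 33-fold higher number from compound 3 to compound 4 (1.52 log units; beyond the scatter). Compound 4 stands at > 100 mg/kg, which is a limit of the assay and not a number. This single added methyl is enough to lose the measurable value at this position, leaving compound 3 as the only compound with a number: the limit of > 100 mg/kg in this assay, at which 3 of the 4 values shown sit.

As far as these compounds go, it remains open whether this loss is specific to methyl or extends to other groups on this aromatic carbon, such as fluorine, chlorine, ethyl or an amine, and whether methyl on the other aromatic carbons of the ring would read the same way. Also open, from the compounds shown here alone, is how far the rest of compound 3 can change while a number is kept, for instance with a propionyl group in place of the acetyl group or a longer chain in place of the methyl groups on the amide side.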